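Second chloro on the core of compound 1

The source may report more compounds than this note shows. Statements on the series, on what has been measured and on what is new or still open speak of the compounds shown alone.

Compound 1 `ClCc1ccc(Cn2cnc3c(Cl)ncnc32)cc1` was examined in a functional assay on KM12 cells (Homo sapiens) for cytotoxicity, read by sulforhodamine B assay, with a stated time of 48 h (a higher number here means a weaker inhibitor of growth, a lower number a stronger inhibitor of growth), where compound 1 gives 2140 nM. This is the highest of the two numbers recorded so far. The other compound, compound 2 `ClCc1cccc(Cn2cnc3ncnc(Cl)c32)c1`, gives in this assay a value of 1860 nM, which is only slightly lower and lies within the scatter of the method, so the two cannot be ranked against each other. Going by the values given here, compound 2 differs from compound 1 in more than one place, so no single step between them is computed.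

Compound 3 `ClCc1ccc(Cn2cnc3c(Cl)nc(Cl)nc32)cc1` has not yet been measured. Compared with compound 1, the change is chloro in place of hydrogen on an aromatic carbon. Among the compounds with values here, no measured pair shows what such a change does here, so nothing about its size is known from the data. Compound 3 is expected to give a value near that of compound 1, with at most a small step toward a lower number, an estimated step of a 1.4-fold lower number from compound 1 to compound 3 (0.15 log units; within the scatter) in this assay, which may well stay within the scatter. Compound 3 is therefore estimated at 1500 nM, with a range from 500 nM to 5000 nM.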

Compound 3, concentration for 50% growth inhibition: 1820 nM
Compound 3: the middle estimate sits 1.2-fold (0.08 log units) below what was measured; low and high end bracket the measured number.
By their numbers in this assay, from the lowest: compounds 3, 2 and 1 (each within the scatter of the next).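

In this assay, going by these compounds alone, chloro in place of hydrogen on the aromatic carbon between two ring nitrogen atoms gives a 1.2-fold lower number from compound 1 to compound 3 (0.07 log units; within the scatter), the first step in this set that can be read as a change in one place. It shows that this carbon of the shared core can carry a chloro without a change in growth inhibition that this read-out can distinguish, so hydrogen and chloro cannot be told apart here. Nothing measured in this set accounts for that outcome.

Going by these compounds, whether an amine, a methoxy group or a longer chain on the same carbon would move the number beyond the scatter stays open, as does the question of whether any substituent at this position matters in this assay at all. Also open, on these data alone, is whether the same chloro on the core of compound 2, where the other substituents are placed differently, would give an equally small step.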